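This account rests on a few compounds, and the source may have more. Where it says the series, first, only, none or still open, it means among the compounds named here.

In a functional assay on DU-145 cells (Homo sapiens) for inhibition, read by trypan blue exclusion, with a stated time of 96 h (on this read-out higher numbers stand for weaker inhibition of growth and lower numbers for stronger inhibition of growth), compound 1 (`O=C(O)c1ccc(/C=C(/SCc2ccc(Cl)cc2)C(=O)c2ccc(C(=O)O)cc2)cc1`) stands at > 100000 nM as its reading, and this figure is a limit of the assay, not a number. Two relatives give numbers. Compound 2 (`CSc1ccc(/C=C(\C(=O)c2ccc(Cl)cc2)S(=O)(=O)Cc2ccc(C)cc2)cc1`) gives 10000 nM in the same test, and compound 3 (`COc1ccc(/C=C(\C(=O)c2ccc(Cl)cc2)S(=O)(=O)c2ccc(Br)cc2)cc1O`) gives 10000 nM there. Neither carries a carboxy group, but both also differ from compound 1 in other places, so they are only a loose guide. Among the compounds with values here, no pair of measured compounds differs in just one place, so no direct step is available for comparison.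

Compound 4 (`COc1ccc(/C=C(/SCc2ccc(Cl)cc2)C(=O)c2ccc(C(=O)O)cc2)cc1`) departs from compound 1 in one place, methoxy in place of carboxy on an aromatic carbon in the counted difference. In words, this is methoxy in place of carboxy on an aromatic carbon, para to a large group, turning a 4-carboxyphenyl into a 4-methoxyphenyl. The other carboxy group stays.

A moderate step towards lower numbers, meaning stronger inhibition of growth, is expected in this assay for this change. Compound 2, at 10000 nM without any carboxy group, shows what such relatives can reach. Compound 4 keeps one carboxy group. The estimated change is an at least 3.3-fold lower number from compound 1 to compound 4 (0.52 log units; beyond the scatter) on this reading. For compound 4 the estimate is 30000 nM with an expected range from 8000 nM to 100000 nM in this test.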

Compound 4, concentration for 50% growth inhibition: 10000 nM
For compound 4 the middle estimate is 3.0-fold (0.48 log units) above the measured one, and the stated range covers the measured number.
By their numbers in this assay, from the lowest: compounds 2, 3 and 4 (each within the scatter of the next). At a limit, above all of these: compound 1.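

In this assay, within the data shown here, the new pair gives the first direct reading of a single change: methoxy in place of carboxy on an aromatic carbon, with the rest of the structure untouched, comes with an at least 10-fold lower number from compound 1 to compound 4 (1.00 log units; beyond the scatter). Compound 4 still keeps its other carboxy group and gives 10000 nM, so removing both carboxy groups is not needed for this compound to give a number in this test. The reading for compound 1 is a limit of the assay and not a number, so the step can be read only as a minimum and its true size stays unknown: the limit of > 100000 nM in this assay, at which 1 of the 4 values shown sits.

A single swap also cannot separate the loss of the carboxy group from the arrival of the methoxy group, and a hydroxy, a methyl or a chlorine at the same place would help to tell these two apart. Going by these compounds, what happens when the remaining carboxy group of compound 4 is replaced by a methoxy group or an amine also stays open, as does whether such a swap there would bring a step of similar size.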